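This account rests on a few compounds, and the source may have more. Where it says the series, first, only, none or still open, it means among the compounds named here.

Compound 3, `CCCCCCCCSc1nc(N)nc2c1ncn2/C=C1/CC1(CO)CO`, stands at the ceiling of the numbers shown: in an ADME assay on Akata cells (Homo sapiens) for cytotoxicity, with a stated time of 7 days (on this read-out higher numbers stand for lower toxicity in this test and lower numbers for higher toxicity in this test), compound 3 gives > 20000 nM, which is a limit of the assay and not a measured number. Compound 1, `CCCCSc1nc(N)nc2c1ncn2/C=C1/CC1(CO)CO`, likewise gives > 20000 nM, a limit. Compound 2, `Nc1nc(NC2CC2)c2ncn(/C=C3/CC3(CO)CO)c2n1`, gives > 20000 nM, again a limit. All three sit at the limit of > 20000 nM in this assay, at which 3 of the 3 values shown sit, so the steps a step that the two limits leave unreadable from compound 1 to compound 2, a step that the two limits leave unreadable from compound 1 to compound 3 and a step that the two limits leave unreadable from compound 2 to compound 3 cannot be read. Compound 4, `CC(C)Nc1nc(N)nc2c1ncn2/C=C1/CC1(CO)CO`, differs from compound 3 by isopropylamino in place of octylsulfanyl on an aromatic carbon. The step between an amino and a sulfanyl group on that carbon, a step that the two limits leave unreadable from compound 2 to compound 3, shows no readable size, so no move beyond the scatter is expected. Compound 4 is therefore estimated at 30000 nM, between 15000 nM and 80000 nM. The expected step is a step that the limit leaves unreadable from compound 3 to compound 4, with a limit again the likeliest outcome.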

Compound 4, half-maximal cytotoxic concentration: > 24000 nM
Compound 4 was reported as a limit (the forecaster's own chance of this, stated with the estimate: 80%); the middle value is on the limit's open side.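

Compound 4, like compound 1, compound 2 and compound 3, gives only a limit, so none of its steps to them can be read. The compounds shown leave open whether the group on that aromatic carbon changes the result in this assay at all.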